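The compounds below may be only part of what the source reports. "The series", "measured", "known", "first", "only" and "open" are said of these compounds alone.

Measured so far:
compound 1 `Cc1ccnc(/C(N)=N/NC(=S)N2CCN(c3ccccn3)CC2)c1`, 42.5%
compound 2 `Cc1cccc(/C(N)=N/NC(=S)N2CCCC2)n1`, 56.8%
compound 3 `N/C(=N\NC(=S)N1CCCC1)c1ccccn1`, 38.5%

All three were read in a functional assay on HeLa cells (Homo sapiens) for cytotoxicity, read by MTT assay, with a stated time of 72 h, tested at 3 uM; a higher number here means more inhibition of growth at the concentration tested, a lower number less inhibition of growth. Compound 1 and compound 3 lie within the scatter of each other; compound 2 gives the higher number of the three. The step of a number 18.3 percentage points lower from compound 2 to compound 3 (beyond the scatter) follows (hydrogen in place of methyl on an aromatic carbon). Compound 4 `N/C(=N\NC(=S)N1CCN(c2ccccn2)CC1)c1ccccn1` is not yet measured and differs from compound 1 by hydrogen in place of methyl on an aromatic carbon. The difference between the core of compound 1 and the core of compound 2 is not broken down here. The two changes are the same kind of change, but the place is not the same: in compound 2 the methyl sits next to the ring nitrogen, in compound 1 opposite the ring nitrogen. The step expected in this assay is a number 12.5 percentage points lower from compound 1 to compound 4 (beyond the scatter), which rests on a number 18.3 percentage points lower from compound 2 to compound 3 (beyond the scatter) and is taken somewhat smaller as the place differs. For compound 4 the expected value is 30%, with a likely range from 15% to 45%.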

Compound 4, percent growth inhibition at one concentration: 24.4%
The estimate for compound 4 lay 5.6 percentage points above the measured number; low and high end bracket the measured number.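

In this assay, the change 4-methylpyridin-2-yl to pyridin-2-yl gives a number 18.1 percentage points lower from compound 1 to compound 4 (beyond the scatter). Set beside the earlier step, the loss of the methyl carries over from one core to the other at nearly the same size: the same change on two cores in this assay, a number 18.3 percentage points lower (beyond the scatter) from compound 2 to compound 3 and a number 18.1 percentage points lower (beyond the scatter) from compound 1 to compound 4, 0.2 percentage points apart, within the scatter of two such steps This agreement rests on two pairs in a single assay at a single concentration, with the methyl not in the same place in compound 1 and compound 2, and it neither gives a rule for the wider series nor explains the drop.

The compounds shown leave open whether an ethyl, a methoxy or an amine at the place opposite the ring nitrogen would raise the number as methyl does. They also leave open whether the step would hold on a third core.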